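A few compounds are considered here, and "the series" means these few. Any claim that something is new, unique, unknown or untested is made for them only; others in the source may bear on it.

Compound 1 `Cc1ccc(S(=O)(=O)Nc2ccc3oc(-c4ccccc4)nc3c2)cc1` gives > 63000 nM in an assay on isolated protein for inhibition of malate dehydrogenase, mitochondrial (Sus scrofa), with stated times of 45 min and 30 min; a lower number here means a stronger inhibitor, a higher number a weaker inhibitor. Compound 2 `O=S(=O)(Nc1ccc(-c2nc3ccccc3o2)cc1)c1ccccc1Cl` gives > 63000 nM in this assay. Compound 3 `O=S(=O)(Nc1ccc(-c2nc3ccccc3o2)cc1)c1ccc(F)c(C(F)(F)F)c1` gives > 63000 nM in this assay.

Each of these three values is a limit of this assay rather than a number, and compound 1 stands at that limit, as the others do (the limit of > 63000 nM in this assay, at which 3 of the 3 values shown sit). Compound 4 `COc1ccc(Cl)cc1S(=O)(=O)Nc1ccc2oc(-c3ccccc3)nc2c1` differs from compound 1 in one place: 5-chloro-2-methoxyphenyl in place of 4-methylphenyl on a sulfonyl sulfur. No measured pair among these compounds shows what such a change does, so there is no step to lean on. Because all three measured compounds sit at the limit (the limit of > 63000 nM in this assay, at which 3 of the 3 values shown sit), compound 4 is expected to stay there as well, with a step that the limit leaves unreadable from compound 1 to compound 4 that is expected to be none beyond the scatter. The estimated value for compound 4 is 90000 nM, from 25000 nM to 300000 nM.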

Compound 4, half-maximal inhibitory concentration: > 63000 nM
Compound 4: only a limit was reported; the forecaster's own chance of this, stated with the estimate: 85%; the middle value does not contradict the limit.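

No step can be read from compound 1 to compound 4, since both values are limits: (the limit of > 63000 nM in this assay, at which 4 of the 4 values shown sit). The compounds shown leave open whether any change on the sulfonyl sulfur would bring a compound within the measurable range of this assay at all.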